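The source may hold more compounds than are shown below. What is called first, only, known or untested is meant among the compounds shown, and "the series" means these compounds.

In a functional assay on HeLa cells (Homo sapiens) for cytotoxicity, read by MTT assay, with a stated time of 72 h (a lower number here means a stronger inhibitor, a higher number a weaker inhibitor), compound 1 `O=C(/C=C/c1cccc(Cl)c1Cl)Nc1cc2c(Nc3ccc(F)c(Cl)c3)ncnc2cc1O[C@H]1CCOC1` gives 30500 nM, and compound 2 `COc1ccc(/C=C/C(=O)Nc2cc3c(Nc4ccc(F)c(Cl)c4)ncnc3cc2O[C@H]2CCOC2)c(OC)c1` gives 26500 nM. Compound 3 `COc1ccc(/C=C/C(=O)Nc2cc3c(Nc4ccc(F)c(Cl)c4)ncnc3cc2OC)c(OC)c1` gives "not determined" (no result reported), so no number is reported for it. Within the data shown here, compound 2 therefore sits alongside compound 1, the only other number, and the step of a 1.2-fold lower number from compound 1 to compound 2 (0.06 log units; within the scatter) shows that exchanging one aryl group for another left the read-out essentially unchanged.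

Compound 4 `O=C(/C=C/c1ccccc1[N+](=O)[O-])Nc1cc2c(Nc3ccc(F)c(Cl)c3)ncnc2cc1O[C@H]1CCOC1` differs from compound 2 in the same region: 2-nitrophenyl in place of 2,4-dimethoxyphenyl on a double-bonded chain carbon bound to a double-bonded chain carbon. Among the measured compounds shown here, the one measured step that bears on it is a 1.2-fold lower number from compound 1 to compound 2 (0.06 log units; within the scatter), which was within the scatter, so no shift beyond the scatter is expected here either. Compound 4 is thus estimated at 28000 nM in this assay, between 12000 nM and 65000 nM. That estimate means a step of a 1.1-fold higher number from compound 2 to compound 4 (0.02 log units; within the scatter), expected to fall within the scatter.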

Compound 4, half-maximal inhibitory concentration: 29600 nM
Compound 4: the middle estimate sits 1.1-fold (0.02 log units) below what was measured; the range from low to high includes it.
By their numbers in this assay, from the lowest: compounds 2, 4 and 1 (each within the scatter of the next).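

In this assay a third substituted phenyl on the double-bonded chain carbon, 2-nitrophenyl, reads the same as 2,4-dimethoxyphenyl (a 1.1-fold higher number from compound 2 to compound 4 (0.05 log units; within the scatter)) and 2,3-dichlorophenyl (a 1.0-fold lower number from compound 1 to compound 4 (0.01 log units; within the scatter)). A nitro-bearing ring thus joins the chlorine-bearing and methoxy-bearing rings, with no step beyond the scatter among these three compounds. No measurement offered here explains this flat result. Still open, as far as these compounds go, is whether a group without a phenyl ring at this place, such as a dimethylamine or a carboxylic acid, would move the number at all.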